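Methoxy-Azine Replacing Dihydrobenzofuran: Canine Clearance Outlook

The source may hold more compounds than are shown below. What is called first, only, known or untested is meant among the compounds shown, and "the series" means these compounds.

Measured compounds:
Compound 1 `COc1ncc([C@@H](CCCCCCc2ccc3c(n2)NCCC3)CC(=O)O)cn1` gives 4.3 mL/min/kg in an in vivo ADME assay on the whole organism (Canis lupus familiaris) for pharmacokinetics; on this read-out higher numbers stand for fast clearance and lower numbers for slow clearance.
Compound 2 `O=C(O)C[C@H](CCCCCCc1ccc2c(n1)NCCC2)c1ccc2c(c1)OCC2` gives 7.9 mL/min/kg in this assay.

On the two numbers shown, compound 2 and compound 1 sit within the scatter of each other: a 1.8-fold higher number from compound 1 to compound 2 (0.26 log units; within the scatter). Compound 3 `COc1ccc([C@@H](CCCCCCc2ccc3c(n2)NCCC3)CC(=O)O)cn1` carries the change (a group of 8 heavy atoms (6 carbon, 1 nitrogen, 1 oxygen; one six-membered aromatic ring with 1 hetero atom) in place of a group of 9 heavy atoms (8 carbon, 1 oxygen; one five-membered non-aromatic ring with 1 hetero atom, one six-membered aromatic ring of carbon only), on a saturated chain carbon bound to two saturated chain carbons). For the measured compounds named here, the only step that bears on it is the one from compound 1 to compound 2, and it was within the scatter, so no step beyond the scatter is expected in this assay. Compound 3 is expected to give 5.5 mL/min/kg, within a range from 2.5 mL/min/kg to 12 mL/min/kg. The expected step is a 1.4-fold lower number from compound 2 to compound 3 (0.16 log units; within the scatter).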

Compound 3, clearance in the Canis lupus familiaris assay: 5.1 mL/min/kg
Estimate against measurement, compound 3: 1.1-fold (0.03 log units) above; measured number inside the range.
By their numbers in the Canis lupus familiaris assay, from the lowest: compounds 1, 3 and 2 (each within the scatter of the next).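

On the saturated chain carbon bound to two saturated chain carbons, the Canis lupus familiaris assay does not separate 6-methoxypyridin-3-yl from either group it was set against: a 1.5-fold lower number from compound 2 to compound 3 (0.19 log units; within the scatter), and a 1.2-fold higher number from compound 1 to compound 3 (0.07 log units; within the scatter). a physicochemical assay for lipophilicity (on this read-out lower numbers stand for lower lipophilicity and higher numbers for higher lipophilicity), does separate one of these pairs, with compound 2 at 2.39 and compound 3 at 1.67, a number 0.72 log units lower from compound 2 to compound 3 (beyond the scatter). For this pair, then, a partition coefficient step beyond the scatter came with a clearance step within it.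

From the compounds shown here alone, what a morpholine or a nitrile-bearing phenyl on this carbon would give in the Canis lupus familiaris assay remains open. So does whether clearance and partition coefficient are linked at this position.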